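Formyl for hydroxymethyl in a four-compound series

The compounds below may be only part of what the source reports. "The series", "measured", "known", "first", "only" and "open" are said of these compounds alone.

Compound 1 `CC1(C)O[C@H]2CC[C@@](C)(O)[C@@H](CC[C@@H]3C(CO)=CC[C@H]4[C@H](CC[C@]4(C)O)C3(C)C)[C@]2(C)CCC1=O` carries a hydroxymethyl group on a ring double bond. In a functional assay on MCF7 cells (Homo sapiens) for antiproliferative activity, read by MTT assay, with a stated time of 72 h (a lower number here means a stronger inhibitor, a higher number a weaker inhibitor), compound 1 gives only a limit, > 50000 nM. Compound 2 `CC1(C)O[C@H]2CC[C@@](C)(O)[C@@H](CC[C@@H]3C(CO)=CC[C@H]4[C@H](CC[C@]4(C)O)C3(C)C)[C@]2(C)CC[C@@H]1O` differs from compound 1 in the core; that difference is not broken down here. In this assay compound 2 likewise gives only a limit, > 50000 nM. Compound 3 `CC1(C)O[C@H]2CC[C@@](C)(O)[C@@H](CC[C@@H]3C(C=O)=CC[C@H]4[C@H](CC[C@]4(C)O)C3(C)C)[C@]2(C)CCC1=O` arises from compound 1 by formyl in place of hydroxymethyl on a double-bonded ring carbon. In this assay compound 3 also gives only a limit, > 50000 nM. The step that the two limits leave unreadable from compound 1 to compound 3 therefore cannot be read, since (the limit of > 50000 nM in this assay, at which 3 of the 3 values shown sit). Compound 4 `CC1(C)O[C@H]2CC[C@@](C)(O)[C@@H](CC[C@@H]3C(C=O)=CC[C@H]4[C@H](CC[C@]4(C)O)C3(C)C)[C@]2(C)CC[C@@H]1O` arises from compound 2 by the same change, (formyl in place of hydroxymethyl on a double-bonded ring carbon). Compound 4 is expected to remain at the limit as well, estimated at 80000 nM, an expected step that the limit leaves unreadable from compound 2 to compound 4. This expectation rests on compound 3, whose value in this assay is a limit, > 50000 nM.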

Compound 4, half-maximal inhibitory concentration: > 50000 nM
Compound 4 gave a limit, no number; the forecaster's own chance of this, stated with the estimate: 85%; the middle value does not contradict the limit.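

Formyl in place of hydroxymethyl from compound 2 to compound 4 gives no readable step, since both values are limits: the limit of > 50000 nM in this assay, at which 4 of the 4 values shown sit.

Still open, from the compounds shown here alone, is whether formyl in place of hydroxymethyl changes activity at all in this assay.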